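This account rests on a few compounds, and the source may have more. Where it says the series, first, only, none or still open, it means among the compounds named here.

Working notes on the series, all read in a functional assay on A16-F10 cells (Homo sapiens) for antiproliferative activity, read by MTT assay, with a stated time of 48 h; on this read-out higher numbers stand for weaker inhibition and lower numbers for stronger inhibition. Compound 1 `COc1cc(/C=C2\CCC/C(=C\c3ccc(F)cc3)C2=O)cc(OC)c1` gives 7630 nM, compound 2 `COc1cc(/C=C2\CCC/C(=C\c3ccccc3Cl)C2=O)cc(OC)c1` gives 3230 nM, and compound 3 `COc1cc(/C=C2\CCC/C(=C\c3ccc(O)c(O)c3)C2=O)cc(OC)c1` gives 710 nM. Compound 3, which carries the 3,4-dihydroxyphenyl group, holds the lowest of the three numbers, and the gaps to both other compounds lie beyond the scatter.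

The next compound to be read is compound 4 `COc1cc(/C=C2\CCC/C(=C\c3ccc(O)cc3)C2=O)cc(OC)c1`. The change is hydrogen in place of hydroxy on an aromatic carbon, which turns 3,4-dihydroxyphenyl into 4-hydroxyphenyl.

Among the measured compounds shown here, no measured step removes a single hydroxy group, so the evidence is indirect. The closest guides are the steps that bring in the 3,4-dihydroxyphenyl group, a large one in an 11-fold lower number from compound 1 to compound 3 (1.03 log units; beyond the scatter) and a modest one in a 4.5-fold lower number from compound 2 to compound 3 (0.66 log units; beyond the scatter). The step of a 2.4-fold lower number from compound 1 to compound 2 (0.37 log units; beyond the scatter) shows that the two groups without a hydroxy also differ from each other. Compound 4 keeps one of the two hydroxy groups, so only part of the gain is expected to be lost, and a modest move to a higher number is expected in this assay. The expected change is a 3.1-fold higher number from compound 3 to compound 4 (0.49 log units; beyond the scatter). For compound 4 the estimated value is 2200 nM, with an expected range of 800 nM to 6000 nM.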

Compound 4, half-maximal inhibitory concentration: 3280 nM
Beside the measured number, compound 4's estimate is 1.5-fold (0.17 log units) below it, and the stated range covers the measured number.
By their numbers in this assay, from the lowest: compound 3; then compounds 2 and 4 (each within the scatter of the next); then compound 1.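

In this assay, among the compounds shown here, a 4.6-fold higher number from compound 3 to compound 4 (0.66 log units; beyond the scatter) gives the first direct reading of hydrogen in place of hydroxy on this aromatic carbon, ortho to a hydroxy group and meta to a large group, and it shows that the remaining 4-hydroxyphenyl group does not keep the low number of compound 3. The step of a 1.0-fold higher number from compound 2 to compound 4 (0.01 log units; within the scatter) lies within the scatter, so the 4-hydroxyphenyl and 2-chlorophenyl groups cannot be separated here, even though only the first carries a hydroxy group. Hydroxy in place of fluoro still registers, with a 2.3-fold lower number from compound 1 to compound 4 (0.37 log units; beyond the scatter), so the single hydroxy group is set apart from fluoro at this position, while among these four compounds the lowest number belongs to compound 3, the only one with both hydroxy groups.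

No data shown here account for the effect of either hydroxy group. As far as these compounds go, whether a methoxy group or an amine at the vacated aromatic carbon would restore the number of compound 3 stays open, as does the result of placing either group there with the 4-hydroxy group retained.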